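Swapping the Amine Tail: From Compound 3 to Compound 4

This account rests on a few compounds, and the source may have more. Where it says the series, first, only, none or still open, it means among the compounds named here.

Measured so far:
Compound 1 `COc1cc2c(Nc3nc4ccc(C(=O)Nc5c(C)cccc5C)cc4s3)ncnc2cc1OCCCN1CCCCC1` gives a limit of the assay, > 100000 nM.
Compound 2 `COc1cc2c(Nc3nc4ccc(C(=O)Nc5c(C)cc(C)cc5C)cc4s3)ncnc2cc1OCCCN1CCCCC1C` gives 5700 nM.
Compound 3 `CCN(CC)CCCOc1cc2ncnc(Nc3nc4ccc(C(=O)Nc5c(C)cc(C)cc5C)cc4s3)c2cc1OC` gives 6800 nM.

In a functional assay on DLD-1 cells (Homo sapiens) for cytotoxicity, read by WST assay, with a stated time of 72 h (a lower number here means a stronger inhibitor, a higher number a weaker inhibitor), compound 3 stands at the higher of the two values that are actual numbers; compound 2 sits beside it, and the gap between the two, a 1.2-fold higher number from compound 2 to compound 3 (0.08 log units; within the scatter), lies within the usual scatter. The value for compound 1 is a limit of the assay rather than a number, so it cannot be ranked against the others.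

Compound 4 `COc1cc2c(Nc3nc4ccc(C(=O)Nc5c(C)cc(C)cc5C)cc4s3)ncnc2cc1OCCCN1CCCCC1` differs from compound 3 by one change: piperidin-1-yl in place of diethylamino on a saturated chain carbon, three bonds along the chain from an oxygen on an aromatic ring. For the measured compounds named here, the only measured step that bears on this change is a 1.2-fold higher number from compound 2 to compound 3 (0.08 log units; within the scatter), which also exchanges one amine for another on the same chain and stays within the scatter. On that basis the change from compound 3 to compound 4 is expected to bring no step beyond the scatter, a 1.0-fold lower number from compound 3 to compound 4 (0.02 log units; within the scatter). Compound 4 is therefore estimated at 6500 nM, with a range from 2500 nM to 25000 nM.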

Compound 4, half-maximal inhibitory concentration: 24500 nM
The estimate for compound 4 lay 3.8-fold (0.58 log units) below the measured number; the range from low to high includes it.
By their numbers in this assay, from the lowest: compounds 2 and 3 (each within the scatter of the next); then compound 4. At a limit, above all of these: compound 1.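

The amines on this chain are not interchangeable: in this assay, piperidin-1-yl in place of diethylamino gives a 3.6-fold higher number from compound 3 to compound 4 (0.56 log units; beyond the scatter), even though the earlier exchange of amines gave only a 1.2-fold higher number from compound 2 to compound 3 (0.08 log units; within the scatter). The methyl on the saturated ring carbon matters too, as hydrogen in its place gives a 4.3-fold higher number from compound 2 to compound 4 (0.63 log units; beyond the scatter) and leaves compound 4 with the highest number among the compounds not at a limit. Methyl in place of hydrogen on an aromatic carbon gives an at least 4.0-fold lower number from compound 1 to compound 4 (0.61 log units; beyond the scatter), a step that starts from a limit rather than a number: the limit of > 100000 nM in this assay, at which 1 of the 4 values shown sits.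

Going by these compounds, what a morpholin-4-yl or pyrrolidin-1-yl group would do at the end of this chain remains open. So does the effect of a longer chain carrying the same amines.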